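Swapping a Fluorine for a Bromine on the Pendant Ring

The source may report more compounds than this note shows. Statements on the series, on what has been measured and on what is new or still open speak of the compounds shown alone.

Compound 2 `C=CCn1c(=O)/c(=C\c2cccc(F)c2)[nH]c(=O)/c1=C\c1ccccc1OC` is the highest of three numbers in a functional assay on U-937 cells (Homo sapiens) for cytotoxicity, read by CCK-8 assay, with a stated time of 72 h (on this read-out higher numbers stand for weaker inhibition and lower numbers for stronger inhibition), where compound 2 gives 2500 nM. Compound 1 `COc1ccccc1/C=c1\c(=O)[nH]/c(=C/c2cccc(Cl)c2Cl)c(=O)n1C` gives 100 nM in this assay, and compound 3 `COc1ccccc1/C=c1\c(=O)[nH]/c(=C/c2ccccc2Cl)c(=O)n1C` gives 100 nM, so compound 2 sits well apart from both. Compound 4 `C=CCn1c(=O)/c(=C\c2cccc(Br)c2)[nH]c(=O)/c1=C\c1ccccc1OC` differs from compound 2 by bromo in place of fluoro on an aromatic carbon, turning 3-fluorophenyl into 3-bromophenyl. Within the data shown here, the only measured step, no change at the digits printed from compound 1 to compound 3 (within the scatter), changed a halogen on a different ring and had no effect beyond the scatter, so it bears only loosely here. Accordingly, only a modest shift in this assay is expected, with no clear direction. The estimate for compound 4 is 1500 nM, within 500 nM to 5000 nM, meaning an expected step of a 1.7-fold lower number from compound 2 to compound 4 (0.22 log units; within the scatter).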

Compound 4, half-maximal inhibitory concentration: 1100 nM
Compound 4: the middle estimate sits 1.4-fold (0.13 log units) above what was measured; measured number inside the range.
By their numbers in this assay, from the lowest: compounds 1 and 3 (each within the scatter of the next); then compound 4; then compound 2.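

With bromo in place of fluoro on the pendant ring, meta to a large group, this assay shows a 2.3-fold lower number from compound 2 to compound 4 (0.36 log units; beyond the scatter). This is a modest step, but unlike the earlier swap of chloro for hydrogen, it lies beyond the usual scatter, so the choice of halogen at this position can shift the number. No measurement here gives a reason for this shift.

Still open, on these data alone, is whether chloro at this position would give a number between those of the fluoro and bromo compounds. Also open, as far as these compounds go, is how a non-halogen group there, such as an amine or a nitrile, would behave.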